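Aryl-piperazine acetamides: nitro for methoxy on the aryl ring

A few compounds are considered here, and "the series" means these few. Any claim that something is new, unique, unknown or untested is made for them only; others in the source may bear on it.

Working notes on a short series sharing one core. Compound 1 `CCN1CCN(CC(=O)Nc2nc3ccccc3[nH]2)CC1` and compound 2 `COc1ccc(N2CCN(CC(=O)Nc3nc4ccccc4[nH]3)CC2)cc1` differ by 4-methoxyphenyl in place of ethyl on an amine nitrogen in a ring. In a functional assay, read by spectrophotometry, with a stated time of 30 min, tested at 50 ug/mL (on this read-out lower numbers stand for a weaker effect and higher numbers for a stronger effect at the one concentration tested), compound 1 gives 35.7%, and compound 2 gives 25.8%. The step of a number 9.9 percentage points lower from compound 1 to compound 2 (within the scatter) is within the scatter, so compound 2 cannot be separated from compound 1 on these numbers; the two readings are of one size.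

Compound 3 `O=C(CN1CCN(c2ccc([N+](=O)[O-])cc2)CC1)Nc1nc2ccccc2[nH]1` is the next member, not yet measured. Its difference from compound 2 is nitro in place of methoxy on an aromatic carbon. Among the measured compounds shown here, no measured pair shows nitro in place of methoxy on an aromatic carbon, so nothing bears directly on this change. For the measured compounds named here, the single measured step, from ethyl to 4-methoxyphenyl, was itself within the scatter, and the two values sit close together. With no reading to suggest otherwise, no step beyond the scatter is expected from compound 2 to compound 3 in this assay; the expected step is a number 1.2 percentage points higher from compound 2 to compound 3 (within the scatter). For compound 3 the estimated value in this assay is 27%, with a range from 10% to 45%.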

Compound 3, a percentage reported as activity, at one concentration (the size of the read-out at that concentration, not a potency): 44.8%
Estimate against measurement, compound 3: 17.8 percentage points below; the range from low to high includes it.
By their numbers in this assay, from the lowest: compounds 2, 1 and 3 (each within the scatter of the next, the first and the last beyond it).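

In this assay, among the compounds shown here, nitro in place of methoxy on an aromatic carbon, para to a large group, gives a number 19 percentage points higher from compound 2 to compound 3 (beyond the scatter), the first step to pass beyond the scatter, so the group at this position can shift the reading measurably, which the step from ethyl to 4-methoxyphenyl could not show. The separation holds for this one pair only: 4-nitrophenyl in place of ethyl gives a number 9.1 percentage points higher from compound 1 to compound 3 (within the scatter), so compound 3 and compound 1 are of one size on these numbers, and the modest step does not set compound 3 apart from the whole series. Nothing at hand gives a reason for the step between the methoxy and nitro compounds.

The compounds shown leave open whether the step belongs to the entering nitro or to the leaving methoxy, a question that an amine, a chlorine or a plain hydrogen on the same aromatic carbon would bear on. They also leave open whether the difference between compound 2 and compound 3 would hold at other concentrations, since each reading is a size at one concentration and not a potency.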